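A few compounds are considered here, and "the series" means these few. Any claim that something is new, unique, unknown or untested is made for them only; others in the source may bear on it.

Compound 1, `CCN(CC)C(=O)Cc1c(-c2ccc(OC(C)C)cc2)nn2c(C)cc(C)nc12`, gives 2.2 nM in an assay on isolated protein (kidney, strain Wistar) for displacement of a labelled ligand from Translocator protein (Rattus norvegicus), read by scintillation counting, with a stated time of 90 min; a higher number here means a weaker inhibitor, a lower number a stronger inhibitor.
Compound 2, `CCN(CC)C(=O)Cc1c(-c2ccc(OCC3CCCC3)cc2)nn2c(C)cc(C)nc12`, gives 2.1 nM in this assay.
Compound 3, `CCN(CC)C(=O)Cc1c(-c2ccc(OCc3ccccc3)cc2)nn2c(C)cc(C)nc12`, gives 0.99 nM in this assay.

Compound 2 holds the second highest of these three numbers: a 1.0-fold lower number from compound 1 to compound 2 (0.02 log units; within the scatter), while a 2.1-fold lower number from compound 2 to compound 3 (0.33 log units; beyond the scatter). Compound 4, `CCN(CC)C(=O)Cc1c(-c2ccc(OCc3cccc(F)c3)cc2)nn2c(C)cc(C)nc12`, differs from compound 2 in one place: 3-fluorophenyl in place of cyclopentyl on a saturated chain carbon bound to an oxygen on an aromatic ring. Among the measured compounds shown here, the step that bears on this most directly is a 2.1-fold lower number from compound 2 to compound 3 (0.33 log units; beyond the scatter), and the parallel step a 2.2-fold lower number from compound 1 to compound 3 (0.35 log units; beyond the scatter) points the same way; neither covers the fluorine, which no measured pair tests. A modest lowering of the number is therefore expected, of about the size seen from compound 2 to compound 3. For compound 4 the expected step is a 2.1-fold lower number from compound 2 to compound 4 (0.32 log units; beyond the scatter). Compound 4 is estimated at 1 nM in this assay, within a range from 0.5 nM to 2.2 nM.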

Compound 4, inhibition constant: 0.47 nM
Compound 4: the middle estimate sits 2.1-fold (0.33 log units) above what was measured; the measured number lies below the stated range.
By their numbers in this assay, from the lowest: compound 4; then compound 3; then compounds 2 and 1 (each within the scatter of the next).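

Fluoro in place of hydrogen on an aromatic carbon, which no earlier pair tested, has its own effect here: there is a 2.1-fold lower number from compound 3 to compound 4 (0.32 log units; beyond the scatter) in the benzyl series. Added to the change of ring, it gives a 4.5-fold lower number from compound 2 to compound 4 (0.65 log units; beyond the scatter) and, starting from isopropyl, a 4.7-fold lower number from compound 1 to compound 4 (0.67 log units; beyond the scatter) in the same direction. Nothing measured here explains this gain. As far as these compounds go, whether chloro, methoxy or a nitrile in place of that fluorine would lower the number as well remains open. So does the effect of an amine or a carboxylic acid on this ring.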